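The compounds below may be only part of what the source reports. "The series", "measured", "known", "first", "only" and "open" are said of these compounds alone.

Working notes on the series. Three members share one core and differ only in the substituent on the six-membered aromatic ring. In a functional assay on A549 cells (Homo sapiens) for cytotoxicity, read by XTT assay, with a stated time of 24 h (a higher number here means a weaker inhibitor, a lower number a stronger inhibitor), compound 1 `Cn1nnnc1SCC(=O)N/N=C/c1ccc(Cl)cc1` gives 100000 nM, compound 2 `Cn1nnnc1SCC(=O)N/N=C/c1ccccc1[N+](=O)[O-]` gives 1600000 nM, and compound 3 `Cn1nnnc1SCC(=O)N/N=C/c1cccc(F)c1` gives 6320000 nM. Within this assay compound 2 stands second highest of the three: compound 3 sits above it beyond the scatter, and compound 1 sits below it beyond the scatter. Within the data shown here, no two measured members differ in a single place, so no step is known. Compound 4 `Cn1nnnc1SCC(=O)N/N=C/c1ccccc1O` is obtained from compound 2 by hydroxy in place of nitro on an aromatic carbon. A modest step toward a lower number is expected, a 1.6-fold lower number from compound 2 to compound 4 (0.20 log units; within the scatter), without strong grounds in the data for its direction. For compound 4 the expected value is 1000000 nM, with a range from 200000 nM to 5000000 nM.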

Compound 4, half-maximal inhibitory concentration: > 10000000 nM
Compound 4 was reported as a limit; the forecaster's own chance of this, stated with the estimate: 15%; middle value at least 10-fold (1.00 log units) from the limit.
By their numbers in this assay, from the lowest: compound 1; then compound 2; then compound 3. At a limit, above all of these: compound 4.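

In this assay compound 4 gives > 10000000 nM as a limit of the assay and not a number. Hydroxy in place of nitro on this aromatic carbon, ortho to a large group, gives an at least 6.2-fold higher number from compound 2 to compound 4 (0.79 log units; beyond the scatter) as the first known step at this position. The step runs toward a higher number, but its full size cannot be read: the limit of > 10000000 nM in this assay, at which 1 of the 4 values shown sits.

On these data alone, it remains open whether an amine or a methoxy group at this position would give a measurable number. Also open, as far as these compounds go, is whether such a number would lie nearer that of compound 2.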